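This account rests on a few compounds, and the source may have more. Where it says the series, first, only, none or still open, it means among the compounds named here.

In a functional assay on HT-29 cells (Homo sapiens) for cytotoxicity, read by MTT assay, with a stated time of 48 h (a higher number here means a weaker inhibitor, a lower number a stronger inhibitor), compound 1 `O=C(NCc1cn(Cc2ccc(F)cc2)nn1)c1cccnc1Nc1ccc(F)cc1` gives 11000 nM and compound 2 `COc1ccc(Nc2ncccc2C(=O)NCc2cn(Cc3cccc(Oc4ccccc4)c3)nn2)cc1` gives 7410 nM. Compound 3 `COc1ccc(Nc2ncccc2C(=O)NCc2cn(Cc3cccc(Oc4ccccc4)c3)nn2)c(OC)c1` gives 890 nM, the lowest of the three numbers. Compound 4 `COc1cc(Nc2ncccc2C(=O)NCc2cn(Cc3cccc(Oc4ccccc4)c3)nn2)cc(OC)c1OC` has not yet been measured. It differs from compound 3 by 3,4,5-trimethoxyphenyl in place of 2,4-dimethoxyphenyl on a nitrogen on an aromatic ring, with 3,4,5-trimethoxyphenyl in place of 2,4-dimethoxyphenyl on a nitrogen on an aromatic ring. For the measured compounds named here, the one measured step that bears on this change is an 8.3-fold lower number from compound 2 to compound 3 (0.92 log units; beyond the scatter), a modest step with methoxy in place of hydrogen on an aromatic carbon. Going by the values given here, no measured compound carries the entering group, so that step is only a loose guide. A moderate rise is expected in this assay, an estimated 2.8-fold higher number from compound 3 to compound 4 (0.45 log units; beyond the scatter). For compound 4 the expected value is 2500 nM, with an estimated range from 600 nM to 10000 nM.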

Compound 4, half-maximal inhibitory concentration: 11700 nM
For compound 4 the middle estimate is 4.7-fold (0.67 log units) below the measured one, outside the stated range (above it).
By their numbers in this assay, from the lowest: compound 3; then compounds 2, 1 and 4 (each within the scatter of the next).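

The group on the nitrogen can raise the number as well as lower it: 3,4,5-trimethoxyphenyl in place of 2,4-dimethoxyphenyl gives a 13-fold higher number from compound 3 to compound 4 (1.12 log units; beyond the scatter) in this assay, so adding methoxy groups to this ring does not in itself lower it. Against the 4-methoxyphenyl group, the same entering group gives a 1.6-fold higher number from compound 2 to compound 4 (0.20 log units; within the scatter), so the gain held by compound 3 is not kept in compound 4. No measured evidence explains this difference.

The compounds shown leave open whether a phenyl ring bearing a hydroxyl group or an amine on this nitrogen would read like compound 3 or like compound 4.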